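Amide variation in the shared-core series

A few compounds are considered here, and "the series" means these few. Any claim that something is new, unique, unknown or untested is made for them only; others in the source may bear on it.

Compound 1 `O=C(CC1CCCC1)Nc1c(C(O)(C(F)(F)F)C(F)(F)F)ccc2ccccc12` carries a cyclopentylmethyl on the carbonyl carbon; in an assay on LtK cells with ATP-sensitive inward rectifier potassium channel 11 (Homo sapiens) as the target (a higher number here means that more compound is needed for the effect, a lower number that less compound is needed), compound 1 gives 81 nM. Compound 2 `O=C(Nc1c(C(O)(C(F)(F)F)C(F)(F)F)ccc2ccccc12)c1ccccc1` carries phenyl there, and in this assay compound 2 gives 44 nM, the lowest of the two numbers in the set; the step of a 1.8-fold lower number from compound 1 to compound 2 (0.27 log units; within the scatter) is within the scatter, so the two stand level. Compound 3 `O=C(Nc1c(C(O)(C(F)(F)F)C(F)(F)F)ccc2ccccc12)c1cccc(Cl)c1Cl` carries 2,3-dichlorophenyl, and in this assay compound 3 reaches only the limit > 10000 nM. That is the limit of > 10000 nM in this assay, at which 1 of the 3 values shown sits. The steps of an at least 120-fold higher number from compound 1 to compound 3 (2.09 log units; beyond the scatter) and an at least 220-fold higher number from compound 2 to compound 3 (2.35 log units; beyond the scatter) are large and beyond the scatter.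

Compound 4 `O=C(Nc1c(C(O)(C(F)(F)F)C(F)(F)F)ccc2ccccc12)c1cnco1` is not yet measured. Against compound 2 the change is 1,3-oxazol-5-yl in place of phenyl on a carbonyl carbon. Within the data shown here, two measured steps bear on it: a 1.8-fold lower number from compound 1 to compound 2 (0.27 log units; within the scatter) shows that exchanging the group on the carbonyl carbon between cyclopentylmethyl and phenyl leaves the number within the scatter, while an at least 220-fold higher number from compound 2 to compound 3 (2.35 log units; beyond the scatter) shows that a 2,3-dichlorophenyl there takes the number to the limit. Among the measured compounds shown here, no measured compound carries a five-membered aromatic ring with hetero atoms on that carbon, so the direction rests on these two steps alone: a small rise in this assay is expected, a 2.5-fold higher number from compound 2 to compound 4 (0.40 log units; beyond the scatter), with some chance of a larger one. Compound 4 is therefore expected to give 110 nM in this assay, with a range from 30 nM to 600 nM.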

Compound 4, half-maximal effective concentration: 24 nM
Estimate against measurement, compound 4: 4.6-fold (0.66 log units) above; measured number below the stated range.
By their numbers in this assay, from the lowest: compounds 4, 2 and 1 (each within the scatter of the next, the first and the last beyond it). At a limit, above all of these: compound 3.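

Working notes on the position: in this assay, 1,3-oxazol-5-yl on the carbonyl carbon stands level with phenyl, a 1.8-fold lower number from compound 2 to compound 4 (0.26 log units; within the scatter), so a five-membered aromatic ring with hydrogen-bond acceptors replaces the six-membered carbon ring with no change beyond the scatter. Against the cyclopentylmethyl group the same ring does separate, a 3.4-fold lower number from compound 1 to compound 4 (0.53 log units; beyond the scatter), although compound 1 and compound 2 stand level with each other, so the three amides form a shallow run in which only the two ends lie beyond the scatter. The 2,3-dichlorophenyl group of compound 3 goes against this flat picture, an at least 410-fold lower number from compound 3 to compound 4 (2.61 log units; beyond the scatter), and its value is a limit, not a number: the limit of > 10000 nM in this assay, at which 1 of the 4 values shown sits.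

Open, from the compounds shown here alone, is whether a single chlorine on the phenyl ring, rather than two, already moves the number towards that limit. Also open, going by these compounds, is whether other five-membered rings such as thiazole or furan, or a pyridine, or an amine or carboxylic acid carried on the ring, keep the number of compound 4 on this carbonyl carbon.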